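The source may report more compounds than this note shows. Statements on the series, on what has been measured and on what is new or still open speak of the compounds shown alone.

Measured in a functional assay on PC-3 cells (Homo sapiens) for antiproliferative activity, read by MTT assay, with a stated time of 72 h; on this read-out lower numbers stand for stronger inhibition and higher numbers for weaker inhibition:
Compound 1 `O=C(N/N=C/c1cccc(Br)c1)Nc1ccc(Oc2ccnc3[nH]ccc23)c(F)c1` gives 4020 nM
Compound 2 `O=C(N/N=C/c1cccc([N+](=O)[O-])c1)Nc1ccc(Oc2ccnc3[nH]ccc23)c(F)c1` gives 5140 nM
Compound 3 `O=C(N/N=C/c1ccc([N+](=O)[O-])cc1)Nc1ccc(Oc2ccnc3[nH]ccc23)c(F)c1` gives 150 nM

Compound 3 has the lowest number of the three, and its gaps to both others lie beyond the scatter. Compound 4 `O=C(N/N=C/c1ccc(F)cc1Cl)Nc1ccc(Oc2ccnc3[nH]ccc23)c(F)c1` keeps the shared core but carries 2-chloro-4-fluorophenyl in place of 4-nitrophenyl on a carbon with a double bond to nitrogen. Two large measured steps show that the group on this carbon can move the number strongly (a 27-fold lower number from compound 1 to compound 3 (1.43 log units; beyond the scatter); a 34-fold lower number from compound 2 to compound 3 (1.53 log units; beyond the scatter)). Compound 2 also carries a nitro group, yet it stays level with compound 1 (a 1.3-fold higher number from compound 1 to compound 2 (0.11 log units; within the scatter)), so a nitro group alone does not go with a low number here. Going by the values given here, compound 4 has no 4-nitrophenyl, and no measured compound carries its new group. A sizeable rise is therefore expected, though its size is uncertain, so the range is wide. The expected change in this assay is (an 8.7-fold higher number from compound 3 to compound 4 (0.94 log units; beyond the scatter)) toward weaker inhibition. For compound 4 the estimated value is 1300 nM, with an expected range from 250 nM to 6000 nM.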

Compound 4, half-maximal inhibitory concentration: 3 nM
Estimate against measurement, compound 4: 430-fold (2.64 log units) above, and the stated range ends above it.
By their numbers in this assay, from the lowest: compound 4; then compound 3; then compounds 1 and 2 (each within the scatter of the next).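

In this assay, going by these compounds alone, the place on a carbon with a double bond to nitrogen has more room than the earlier compounds showed: 4-nitrophenyl gave the lowest number among them, yet 2-chloro-4-fluorophenyl goes much lower (a 50-fold lower number from compound 3 to compound 4 (1.70 log units; beyond the scatter)). The gaps to the two weaker compounds are larger still (a 1700-fold lower number from compound 2 to compound 4 (3.23 log units; beyond the scatter); a 1300-fold lower number from compound 1 to compound 4 (3.13 log units; beyond the scatter)), and since compound 4 has no nitro group, a low number at this place does not depend on one. Nothing available explains why this group gives such a low number.

The compounds shown leave open whether the chlorine, the fluorine or the two together go with the low number. They also leave open how an amine or a methoxy group on this ring would read.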